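This account rests on a few compounds, and the source may have more. Where it says the series, first, only, none or still open, it means among the compounds named here.

Measured in a functional assay on HepG2 cells (Homo sapiens) for antiproliferative activity, read by MTT assay, with a stated time of 72 h; on this read-out lower numbers stand for stronger inhibition and higher numbers for weaker inhibition:
- compound 1 `COc1ncc(-c2ccc3c(c2)N(c2ccccc2)C(=O)CO3)cc1NS(=O)(=O)c1ccc(F)cc1`: 14000 nM
- compound 2 `COc1ncc(-c2ccc3c(c2)N(C2CC2)C(=O)CO3)cc1NS(=O)(=O)c1ccc(F)cc1`: 14400 nM

Compound 2 stands level with compound 1, the two values lying within the scatter of each other, and no other number is available for the series yet. Next is compound 3 `COc1ncc(-c2ccc3c(c2)N(c2ccc(Cl)cc2)C(=O)CO3)cc1NS(=O)(=O)c1ccc(F)cc1`, still unmeasured: 4-chlorophenyl in place of cyclopropyl on an amide-type nitrogen in a ring. Among the compounds with values here, one measured step bears on this, at the same nitrogen: cyclopropyl in place of phenyl, a 1.0-fold higher number from compound 1 to compound 2 (0.01 log units; within the scatter). That step lies within the scatter. Within the data shown here, no measured compound carries the chlorine, so the data say nothing directly about it. Among the measured compounds shown here, with only that step to go on, no step beyond the scatter is expected in this assay. The expected step is small: a 1.2-fold lower number from compound 2 to compound 3 (0.08 log units; within the scatter). For compound 3 the estimated value is 12000 nM, with an expected range of 6000 nM to 25000 nM.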

Compound 3, half-maximal inhibitory concentration: 17900 nM
Compound 3: the middle estimate sits 1.5-fold (0.17 log units) below what was measured; measured number inside the range.
By their numbers in this assay, from the lowest: compounds 1, 2 and 3 (each within the scatter of the next).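

Working notes: in this assay, adding the chlorine to the aromatic ring on the amide-type nitrogen gives the first reading of a substituent at this position (a 1.3-fold higher number from compound 1 to compound 3 (0.11 log units; within the scatter)), and that step lies within the scatter. Replacing cyclopropyl with 4-chlorophenyl, a change from a three-membered non-aromatic ring to a larger, chlorine-bearing aromatic ring, also stays within the scatter (a 1.2-fold higher number from compound 2 to compound 3 (0.09 log units; within the scatter)). Phenyl, cyclopropyl and 4-chlorophenyl therefore stand level on this nitrogen, and no available evidence offers an explanation for that.

Still open, as far as these compounds go, is whether a group of another kind on this nitrogen, such as an aminoethyl chain or a carboxylic acid, would move the value beyond the scatter. The shown compounds also leave open what a change to the 4-fluorophenyl sulfonamide or the methoxy group would do, since both stay the same throughout.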